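The source may report more compounds than this note shows. Statements on the series, on what has been measured and on what is new or still open speak of the compounds shown alone.

Measured so far:
compound 1 `C#CCN(C)Cc1cccc(NC(=O)CCCCCC(=O)NO)c1`: 4630 nM
compound 2 `C#CCN(C)Cc1cccc(NC(=O)CCCCCCC(=O)NO)c1`: 330 nM
compound 3 `C#CCN(C)Cc1ccc(NC(=O)CCCCCCCC(=O)NO)cc1`: 7160 nM

All three were read in a functional assay on PC-3 cells (Homo sapiens) for inhibition, read by MTT assay, with a stated time of 48 h; a lower number here means a stronger inhibitor of growth, a higher number a weaker inhibitor of growth. The step from compound 1 to compound 2 is a 14-fold lower number from compound 1 to compound 2 (1.15 log units; beyond the scatter); the change behind it is (hydroxycarbamoyl)methyl in place of hydroxycarbamoyl on a saturated chain carbon, five bonds along the chain from a carbonyl carbon. Compound 3 gives the highest number of the three; against compound 1 the two values lie within the scatter, against compound 2 the gap is beyond it. How the core of compound 3 differs from the core of compound 1 is not broken down here.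

Compound 4 `C#CCN(C)Cc1ccc(NC(=O)CCCCCCCCC(=O)NO)cc1` is not yet measured. From compound 3 it carries (hydroxycarbamoyl)methyl in place of hydroxycarbamoyl on a saturated chain carbon, seven bonds along the chain from a carbonyl carbon. This is the same kind of change as from compound 1 to compound 2, not the same: there the group sat five bonds along the chain from a carbonyl carbon, here seven bonds along the chain from a carbonyl carbon, and the cores differ. Among the measured compounds shown here, only one measured step is available. Compound 2 gives 330 nM, and compound 3, with a longer chain, gives 7160 nM, so further lengthening is expected to give at most a small step for compound 4, a 1.3-fold higher number from compound 3 to compound 4 (0.10 log units; within the scatter). Compound 4 is estimated at 9000 nM, between 2500 nM and 30000 nM.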

Compound 4, concentration for 50% growth inhibition: 4260 nM
For compound 4 the middle estimate is 2.1-fold (0.32 log units) above the measured one; measured number inside the range.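

In this assay, replacing hydroxycarbamoyl with (hydroxycarbamoyl)methyl on the core of compound 3 gives a 1.7-fold lower number from compound 3 to compound 4 (0.23 log units; within the scatter), so this step cannot be distinguished from repeat-measurement noise. The change therefore does not carry over in size from the core of compound 1 to the core of compound 3: the same change on two cores in this assay, a 14-fold lower number (1.15 log units; beyond the scatter) from compound 1 to compound 2 and a 1.7-fold lower number (0.23 log units; within the scatter) from compound 3 to compound 4, 8.3-fold (0.92 log units) apart, beyond the scatter of two such steps

This does not show what sets the two steps apart, since they differ both in the core and in the place of the change, five bonds along the chain from a carbonyl carbon in one case and seven bonds along the chain from a carbonyl carbon in the other, and two steps cannot separate these factors.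

Still open, on these data alone, is how the chains of compound 3 and compound 4 would read on the core of compound 1, and how the chain of compound 2 would read on the core of compound 3. Also open, as far as these compounds go, is whether any of this holds with a carboxylic acid in place of hydroxycarbamoyl.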